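Swapping the carbamate for a methoxyethyl amine

The source may hold more compounds than are shown below. What is called first, only, known or untested is meant among the compounds shown, and "the series" means these compounds.

Measured compounds:
compound 1 `CCC(C)[C@H](NCC1CCCO1)c1cc(C(F)(F)F)ccc1N1CCN(C(=O)CCc2ccc(Cl)cc2Cl)CC1` gives 780 nM in an assay on HEK293 cells for displacement of a labelled ligand from Melanocortin receptor 4 (Homo sapiens); on this read-out higher numbers stand for weaker inhibition and lower numbers for stronger inhibition
compound 2 `CCC(C)[C@H](NCCN)c1cc(C(F)(F)F)ccc1N1CCN(C(=O)CCc2ccc(Cl)cc2Cl)CC1` gives 56 nM in this assay
compound 3 `CCC(C)[C@H](NC(=O)OC)c1cc(C(F)(F)F)ccc1N1CCN(C(=O)CCc2ccc(Cl)cc2Cl)CC1` gives 2400 nM in this assay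

Compound 3 stands at the highest number of the three, so it is the weakest binder measured here. Compound 4 `COCCN[C@@H](CC(C)C)c1cc(C(F)(F)F)ccc1N1CCN(C(=O)CCc2ccc(Cl)cc2Cl)CC1` has not yet been measured. The change from compound 3 to compound 4 is 1-((2-methoxyethyl)amino)-3-methylbutyl in place of 1-((methoxycarbonyl)amino)-2-methylbutyl on an aromatic carbon; in plain terms, the methoxycarbonyl on the amine nitrogen is replaced by a 2-methoxyethyl chain, and the branching of the alkyl chain shifts by one carbon.

Among the measured compounds shown here, two measured steps bear on this. Going the other way, from an amine carrying an (oxolan-2-yl)methyl chain to the methoxycarbonyl, gave a 3.1-fold higher number from compound 1 to compound 3 (0.49 log units; beyond the scatter), and from an amine carrying a 2-aminoethyl chain it gave a 43-fold higher number from compound 2 to compound 3 (1.63 log units; beyond the scatter). Both show that compounds whose amine nitrogen carries a chain give lower numbers than compound 3. The 2-methoxyethyl chain of compound 4 resembles the (oxolan-2-yl)methyl chain of compound 1 more than the 2-aminoethyl chain of compound 2, so a step of about the size seen for compound 1 is expected, downward, beyond the scatter. For the measured compounds named here, no measured pair speaks to the shifted branching, which widens the range.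

Compound 4 is therefore expected to give 700 nM in this assay, with a range from 200 nM to 2500 nM, an expected step of a 3.4-fold lower number from compound 3 to compound 4 (0.54 log units; beyond the scatter).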

Compound 4, inhibition constant: 620 nM
For compound 4 the middle estimate is 1.1-fold (0.05 log units) above the measured one, within the range that was stated.
By their numbers in this assay, from the lowest: compound 2; then compounds 4 and 1 (each within the scatter of the next); then compound 3.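

In this assay, the move from a methoxycarbonyl on the amine nitrogen to a 2-methoxyethyl chain, made together with the shift in branching, gives a 3.9-fold lower number from compound 3 to compound 4 (0.59 log units; beyond the scatter) and so stands clear of the scatter. Compound 4 and compound 1 cannot be told apart (a 1.3-fold lower number from compound 1 to compound 4 (0.10 log units; within the scatter)), which means that the open 2-methoxyethyl chain with the shifted branching reads the same here as the (oxolan-2-yl)methyl chain with the original branching. The 2-aminoethyl chain stays well apart from the 2-methoxyethyl chain, with an 11-fold higher number from compound 2 to compound 4 (1.04 log units; beyond the scatter) separating them, so among the three compounds with a chain on this nitrogen, only compound 2 stands out, while a chain alone does not bring compound 1 or compound 4 close to it.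

On these data alone, since every step to compound 4 also moves the branching, the share of each change stays open, as does the reading for a 2-hydroxyethyl chain or a longer chain such as 3-aminopropyl on this nitrogen. Nothing given here offers an explanation for these differences.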